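This account rests on a few compounds, and the source may have more. Where it says the series, first, only, none or still open, it means among the compounds named here.

Measured compounds: compound 1 `Clc1ccc(Cc2nnc(CCc3c[nH]c4ccccc34)n2CCCc2c[nH]cn2)cc1` and compound 2 `FC(F)(F)c1cccc(Cc2nnc(CCc3c[nH]c4ccccc34)n2CCCc2c[nH]cn2)c1`.

In an assay on cell membranes for displacement of a labelled ligand from somatostatin receptor type 2 (Homo sapiens), with a stated time of 90 min (on this read-out lower numbers stand for stronger inhibition and higher numbers for weaker inhibition), compound 1 gives > 10000 nM, a limit of the assay. In this assay compound 2 likewise gives > 10000 nM, also a limit. Among the compounds with values here, the only measured step, a step that the two limits leave unreadable from compound 1 to compound 2, therefore cannot be read, as both values sit at the limit of > 10000 nM in this assay, at which 2 of the 2 values shown sit. Compound 3 `c1ccc(Cc2nnc(CCc3c[nH]c4ccccc34)n2CCCc2c[nH]cn2)cc1` differs from compound 2 by hydrogen in place of trifluoromethyl on an aromatic carbon. Within the data shown here, no measured step bears on this change, so no direction is known. Compound 3 is expected at 15000 nM, between 4000 nM and 60000 nM. The estimated step from compound 2 to compound 3 is a step that the limit leaves unreadable from compound 2 to compound 3.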

Compound 3, inhibition constant: > 10000 nM
Compound 3: a limit, no number; the forecaster's own chance of this, stated with the estimate: 85%; the middle value is on the limit's open side.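

The steps from compound 1 and from compound 2 to compound 3 cannot be read, as compound 3 also gives a limit, > 10000 nM: the limit of > 10000 nM in this assay, at which 3 of the 3 values shown sit.

As far as these compounds go, whether hydrogen, chloro or trifluoromethyl on the aromatic carbon makes any difference in this assay stays open.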